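Removing a trifluoromethyl group from a weak cytotoxic agent

This account rests on a few compounds, and the source may have more. Where it says the series, first, only, none or still open, it means among the compounds named here.

Two compounds share the same core and differ only in the substituents on the pendant phenyl ring. Compound 1, `O=c1nc2ccccn2cc1Cc1ccccc1`, carries an unsubstituted ring; in a functional assay on MCF7 cells (Homo sapiens) for cytotoxicity, read by MTT assay, with a stated time of 24 h (a lower number here means a stronger inhibitor, a higher number a weaker inhibitor), compound 1 gives 75400 nM. Compound 2, `O=c1nc2ccccn2cc1Cc1ccc(F)cc1C(F)(F)F`, carries both a fluoro group and a trifluoromethyl group; in this assay compound 2 gives 9870 nM. Of these two numbers compound 2 has the lower one, so it is the stronger inhibitor, and the gap to compound 1 lies beyond the usual scatter of the measurement.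

Compound 3, `O=c1nc2ccccn2cc1Cc1ccc(F)cc1`, sits between them in structure. Relative to compound 2 the change is hydrogen in place of trifluoromethyl on an aromatic carbon. Only the fluoro group remains on the ring.

Among the compounds with values here, with no measured pair showing this exact change, the expectation rests on the two numbers above. Because compound 1 gives 75400 nM without either group, taking away the trifluoromethyl group is expected to move compound 3 back toward a weaker number, and the step of a 4.1-fold higher number from compound 2 to compound 3 (0.61 log units; beyond the scatter) is expected to exceed the scatter. Compound 3 is estimated at 40000 nM, within a range of 15000 nM to 100000 nM.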

Compound 3, half-maximal inhibitory concentration: 200000 nM
Estimate against measurement, compound 3: 5.0-fold (0.70 log units) below; measured number above the stated range.
By their numbers in this assay, from the lowest: compound 2; then compound 1; then compound 3.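

In this assay, replacing the trifluoromethyl group on this aromatic carbon with hydrogen gives a 20-fold higher number from compound 2 to compound 3 (1.31 log units; beyond the scatter), so the activity of compound 2 depends heavily on what sits at this one position. The earlier pair differed in two places and could not separate the two groups, but fluoro in place of hydrogen gives a 2.7-fold higher number from compound 1 to compound 3 (0.42 log units; beyond the scatter), showing that the fluoro group alone brings no gain on the unsubstituted ring and instead leaves a weaker inhibitor. The large gain therefore appears only when trifluoromethyl is present alongside the fluoro group, although nothing measured here explains why the numbers move this way.

From the compounds shown here alone, what remains open is whether the trifluoromethyl group would give a similar gain on a ring without the fluoro group, since that would show whether the two groups depend on each other. It is also unclear whether the gain is specific to trifluoromethyl, which a methyl group, a chlorine atom or a methoxy group on the same aromatic carbon could begin to test.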